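The source may hold more compounds than are shown below. What is called first, only, known or untested is meant among the compounds shown, and "the series" means these compounds.

Three compounds of the series carry numbers in an assay on HEK293 cells for binding affinity to 5-hydroxytryptamine receptor 7 (Homo sapiens), read by radioligand binding, tested at 1 uM; a lower number here means less inhibition, a higher number more inhibition at the concentration tested (going by the name of the read-out). Compound 1 `CN1CCCN(CCn2ccc3ccc(O)cc32)CC1` gives 28%, compound 2 `C#Cc1ccc2ccn(CCN3CCCN(C)CC3)c2c1` gives 79%, and compound 3 `CN1CCCN(CCn2ccc3ccc(C(C)(C)O)cc32)CC1` gives 6%. Each pair differs in one place on the same aromatic carbon of the shared core. Ethynyl in place of hydroxy gives a number 51 percentage points higher from compound 1 to compound 2 (beyond the scatter); 1-hydroxy-1-methylethyl in place of hydroxy gives a number 22 percentage points lower from compound 1 to compound 3 (beyond the scatter); and 1-hydroxy-1-methylethyl in place of ethynyl gives a number 73 percentage points lower from compound 2 to compound 3 (beyond the scatter). Compound 3 thus stands lowest of the three, with compound 1 nearest and compound 2 furthest, both gaps beyond the scatter.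

Compound 4 `CN1CCCN(CCn2ccc3ccc(-c4cccnc4)cc32)CC1` continues from compound 3 with a single change: pyridin-3-yl in place of 1-hydroxy-1-methylethyl on an aromatic carbon. Both steps that end in compound 3 bear on this. In each of them the 1-hydroxy-1-methylethyl group that now leaves was the group entering; removing it again reverses a modest loss (a number 22 percentage points lower from compound 1 to compound 3 (beyond the scatter)) or a large loss (a number 73 percentage points lower from compound 2 to compound 3 (beyond the scatter)). Within the data shown here, no measured step shows pyridin-3-yl, or any six-membered aromatic ring with one hetero atom, in this position, so its own contribution is unknown. On the departure of the leaving group alone a rise beyond the scatter is expected, estimated as a number 39 percentage points higher from compound 3 to compound 4 (beyond the scatter), though with wide uncertainty. Compound 4 is accordingly expected to give about 45% in this assay, within 15% to 75%.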

Compound 4, a percentage reported as inhibition, at one concentration (the size of the read-out at that concentration, not a potency): 35%
Compound 4: middle estimate off by 10 percentage points, on the high side; the range from low to high includes it.
By their numbers in this assay, from the lowest: compound 3; then compounds 1 and 4 (each within the scatter of the next); then compound 2.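

Pyridin-3-yl is the first ring seen on this aromatic carbon, and in this assay it recovers part of what 1-hydroxy-1-methylethyl gives up (a number 29 percentage points higher from compound 3 to compound 4 (beyond the scatter)), so a six-membered aromatic ring with 1 hetero atom is accepted here at a level that hydroxy also reaches. The recovery does not extend to the ethynyl level (a number 44 percentage points lower from compound 2 to compound 4 (beyond the scatter)), which leaves ethynyl alone at the top of the four compounds and shows that replacing 1-hydroxy-1-methylethyl with a group with no hydrogen-bond donor does not by itself restore the number of compound 2. Against hydroxy, the ring gives no readable difference (a number 7 percentage points higher from compound 1 to compound 4 (within the scatter)), so two groups that share no feature in their counts except a hydrogen-bond acceptor cannot be told apart at this carbon.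

Open, on these data alone, is whether a nitrile, a primary amine or a carboxylic acid on this carbon would stand nearer compound 2 or nearer compound 1, and whether phenyl or pyridin-4-yl would differ from pyridin-3-yl. No measurement at hand accounts for any of these differences.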